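Aryl replacement on the shared core: notes toward compound 3

A few compounds are considered here, and "the series" means these few. Any claim that something is new, unique, unknown or untested is made for them only; others in the source may bear on it.

Measured so far:
compound 1 `CCOc1cccc(F)c1-c1cccc2nc(Nc3cc(OC)c(OC)c(OC)c3)oc12`: 10800 nM
compound 2 `COc1ccc(F)cc1-c1cccc2nc(Nc3cc(OC)c(OC)c(OC)c3)oc12`: 3700 nM

In an assay on BAF cells for inhibition of ribosomal protein S6 kinase alpha-2 (Mus musculus) (on this read-out higher numbers stand for weaker inhibition and lower numbers for stronger inhibition), compound 2 gives the lowest of the two numbers; the nearest is compound 1, at a 2.9-fold lower number from compound 1 to compound 2 (0.47 log units; beyond the scatter). Compound 3 `COc1cc(Nc2nc3cccc(-c4cccc5cn[nH]c45)c3o2)cc(OC)c1OC` differs from compound 2 by 1H-indazol-7-yl in place of 5-fluoro-2-methoxyphenyl on an aromatic carbon. For the measured compounds named here, the only measured step, from compound 1 to compound 2, exchanges one phenyl substitution pattern for another and does not touch the entering group, so it bears on this change only as a scale of what such aryl swaps have done here. Going by the values given here, for compound 3 the estimate in this assay is 1800 nM, within 250 nM to 12000 nM, meaning an expected 2.1-fold lower number from compound 2 to compound 3 (0.31 log units; beyond the scatter), with the wide range reflecting that no measured compound carries the entering group.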

Compound 3, half-maximal inhibitory concentration: 5700 nM
Compound 3: the middle estimate sits 3.2-fold (0.50 log units) below what was measured, within the range that was stated.
By their numbers in this assay, from the lowest: compounds 2, 3 and 1 (each within the scatter of the next, the first and the last beyond it).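

In this assay, 1H-indazol-7-yl gives a 1.5-fold higher number from compound 2 to compound 3 (0.19 log units; within the scatter) and a 1.9-fold lower number from compound 1 to compound 3 (0.28 log units; within the scatter) on this aromatic carbon. The position therefore accommodates this fused pair of aromatic rings, which carries a hydrogen-bond donor, with the number staying within the scatter of both substituted phenyl compounds. No supporting evidence bears on this result.

Open, on these data alone, is whether replacing the 1H-indazol-7-yl group with 1-methyl-1H-indazol-7-yl would change the number. Also open, as far as these compounds go, is whether an aminomethyl or carboxylic acid substituent on the phenyl group would move it beyond the scatter.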